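The source may report more compounds than this note shows. Statements on the series, on what has been measured and on what is new or still open speak of the compounds shown alone.

Compound 1 `COc1ccc(-c2cc(/C=C/C(=O)c3ccc(N)cc3)[nH]n2)cc1`, compound 2 `COc1ccc(-c2cc(/C=C/C(=O)c3ccc(N)cc3)[nH]n2)cc1OC` and compound 3 `COc1cc(C(=O)/C=C/c2cc(-c3cc(OC)c(OC)c(OC)c3)n[nH]2)cc(OC)c1OC` have all been measured in a functional assay on NCI-H226 cells (Homo sapiens) for cytotoxicity, read by sulforhodamine B assay, with a stated time of 48 h, tested at 0.1 uM; a lower number here means a stronger effect, a higher number a weaker effect of the compound at the concentration tested. Compound 1 gives 84%, compound 2 gives 91% and compound 3 gives 93% in this assay. Compound 2 and compound 1 differ in a single place, (hydrogen in place of methoxy on an aromatic carbon), and that change made a step of a number 7 percentage points lower from compound 2 to compound 1 (within the scatter). How the core of compound 3 differs from the core of compound 2 is not broken down here. Compound 4 `COc1ccc(-c2cc(/C=C/C(=O)c3cc(OC)c(OC)c(OC)c3)[nH]n2)cc1OC` has not yet been measured in this assay. It differs from compound 3 by the same kind of change, (hydrogen in place of methoxy on an aromatic carbon), the place here being in addition meta to a methoxy group (2 heavy atoms). Because the earlier step of a number 7 percentage points lower from compound 2 to compound 1 (within the scatter) stayed within the scatter, compound 4 is expected to show a step of about a number 6 percentage points lower from compound 3 to compound 4 (within the scatter) in this assay. The estimate for compound 4 is 87%, expected to lie between 76% and 97%.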

Compound 4, a percentage reported as activity, at one concentration (the size of the read-out at that concentration, not a potency): 90%
The estimate for compound 4 lay 3 percentage points below the measured number, and the stated range covers the measured number.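

In this assay, putting hydrogen in place of methoxy on the trimethoxy-bearing core gave a step of a number 3 percentage points lower from compound 3 to compound 4 (within the scatter). Set beside the earlier step, the change looks the same on both cores: the same change on two cores in this assay, a number 7 percentage points lower (within the scatter) from compound 2 to compound 1 and a number 3 percentage points lower (within the scatter) from compound 3 to compound 4, 4 percentage points apart, within the scatter of two such steps This agrees with the change carrying over between these two cores, but with both steps inside the scatter, it does not show that the change has any real effect on either core, nor that the same would hold on a third core.

The compounds shown have only methoxy or hydrogen at the changed place, so it stays open whether a larger or different group there, such as a carboxylic acid or an ethoxy chain, would give a step beyond the scatter. Going by these compounds, whether the steps would look the same at a higher concentration also stays open.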